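Swapping butyl(methyl)amino for pyrrolidin-1-yl

The source may hold more compounds than are shown below. What is called first, only, known or untested is meant among the compounds shown, and "the series" means these compounds.

Compound 1 `COc1cc(C(=O)c2sc(N(C)C)nc2N)cc(OC)c1OC` gives "not determined" (no result reported)
Compound 2 `CCN(CC)c1nc(N)c(C(=O)c2cc(OC)c(OC)c(OC)c2)s1` gives "not determined" (no result reported)
Compound 3 `CCCCN(C)c1nc(N)c(C(=O)c2cc(OC)c(OC)c(OC)c2)s1` gives 32000 nM

For the measured compounds named here, in a functional assay on MOLT-4 cells (Homo sapiens) for antiproliferative activity, read by cell counting, with a stated time of 2 days (on this read-out higher numbers stand for weaker inhibition and lower numbers for stronger inhibition), compound 3 gives 32000 nM as the only number at hand, and compound 1 and compound 2 offer no result to compare it with. Compound 4 `COc1cc(C(=O)c2sc(N3CCCC3)nc2N)cc(OC)c1OC` has not yet been measured. Its difference from compound 3 is pyrrolidin-1-yl in place of butyl(methyl)amino on an aromatic carbon and amounts to pyrrolidin-1-yl in place of butyl(methyl)amino on an aromatic carbon. Going by the values given here, no pair of measured compounds shows what such a swap does, so any forecast here is loose. A moderate move toward stronger inhibition is expected, with an estimated 4.0-fold lower number from compound 3 to compound 4 (0.60 log units; beyond the scatter) that could well prove wrong in size. In this assay the estimate for compound 4 is 8000 nM with a range from 1000 nM up to 40000 nM expected.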

Compound 4, half-maximal inhibitory concentration: 260 nM
For compound 4 the middle estimate is 31-fold (1.49 log units) above the measured one, outside the stated range (below it).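

In this assay, pyrrolidin-1-yl in place of butyl(methyl)amino gives a 120-fold lower number from compound 3 to compound 4 (2.09 log units; beyond the scatter) and turns a weak compound into a far stronger one. For the compounds shown here, this is the first comparison at this position, on the aromatic carbon of the five-membered aromatic ring, and it shows that the amino group there has a large effect on the read-out. Whether the five-membered non-aromatic ring is what counts stays open, since the compounds shown include no other ring here, such as piperidin-1-yl or morpholin-4-yl. No measurement at hand says why the step is so large.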